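The source may hold more compounds than are shown below. What is called first, only, known or untested is meant among the compounds shown, and "the series" means these compounds.

Measured in an ADME assay on Vero cells (Chlorocebus sabaeus) for cytotoxicity, read by MTT assay; a lower number here means that less compound is tolerated, a higher number that more compound is tolerated:
- compound 1 `Cn1nc(C(F)(F)F)cc1C(=O)Nc1ccc(S(=O)(=O)N2CCCCC2)cc1`: > 300000 nM (a limit of the assay)
- compound 2 `Cn1nc(C(F)(F)F)cc1C(=O)Nc1ccc(S(=O)(=O)N2CCCCCCC2)cc1`: 16000 nM
- compound 3 `Cn1nc(C(F)(F)F)cc1C(=O)Nc1ccc(S(=O)(=O)n2ccc3ccccc32)cc1`: 13000 nM

Compound 1 gives no number, only a limit of the assay: the limit of > 300000 nM in this assay, at which 1 of the 3 values shown sits. Compound 4 `Cn1nc(C(F)(F)F)cc1C(=O)Nc1ccc(S(=O)(=O)N2CCCCC2C(=O)OC(C)(C)C)cc1` keeps the core of compound 1 and carries tert-butoxycarbonyl in place of hydrogen on a saturated ring carbon, next to the ring nitrogen: tert-butoxycarbonyl in place of hydrogen on a saturated ring carbon.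

Going by the values given here, no measured compound carries this group, so the nearest guides are the two changes that put a larger group on the sulfonyl sulfur. These are an at least 18-fold lower number from compound 1 to compound 2 (1.27 log units; beyond the scatter) and an at least 23-fold lower number from compound 1 to compound 3 (1.36 log units; beyond the scatter), both large. Between those two larger groups, the data show a 1.2-fold lower number from compound 2 to compound 3 (0.09 log units; within the scatter). Those changes replace the whole ring, whereas compound 4 keeps it, so they bear on it only loosely.

A drop beyond the scatter in this assay is therefore expected, though probably a smaller one than the values of compound 2 and compound 3 would suggest, and the expected step is an at least 6.0-fold lower number from compound 1 to compound 4 (0.77 log units; beyond the scatter). For compound 4 the estimated value is 50000 nM, with an expected range from 12000 nM to 250000 nM.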

Compound 4, half-maximal cytotoxic concentration: 38000 nM
Compound 4: middle estimate off by 1.3-fold (0.12 log units), on the high side; low and high end bracket the measured number.
By their numbers in this assay, from the lowest: compounds 3 and 2 (each within the scatter of the next); then compound 4. At a limit, above all of these: compound 1.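

In this assay, tert-butoxycarbonyl in place of hydrogen on a saturated ring carbon, next to the ring nitrogen, gives an at least 7.8-fold lower number from compound 1 to compound 4 (0.89 log units; beyond the scatter) and so moves the number away from the limit held by compound 1. The earlier steps shown here lowered the number only by replacing the whole ring on the sulfonyl sulfur, whereas this one shows that a group added at this place, with the ring kept, is enough for a drop beyond the scatter. The full size of the step cannot be read, because compound 1 has no number, only a limit: the limit of > 300000 nM in this assay, at which 1 of the 4 values shown sits.

As far as these compounds go, whether a carboxylic acid or a methyl ester at this same place would lower the number as well remains open. The compounds shown also do not tell whether the tert-butyl part or the carbonyl goes with the drop.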